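This account rests on a few compounds, and the source may have more. Where it says the series, first, only, none or still open, it means among the compounds named here.

Compound 1 `CC(C)(C)[Si](C)(C)OC[C@H]1O[C@@H](n2cnc3cncnc32)[C@H](O[Si](C)(C)C(C)(C)C)[C@]12OS(=O)(=O)C=C2N` gives 13000 nM in a functional assay on MT4 cells (Homo sapiens) for cytotoxicity; a lower number here means that less compound is tolerated, a higher number that more compound is tolerated. Compound 2 `COc1ncnc2c1ncn2[C@@H]1O[C@H](CO[Si](C)(C)C(C)(C)C)[C@@]2(OS(=O)(=O)C=C2N)[C@H]1O[Si](C)(C)C(C)(C)C` gives 21000 nM in this assay. Going by the values given here, the one step between these two, a 1.6-fold higher number from compound 1 to compound 2 (0.21 log units; within the scatter), puts methoxy in place of hydrogen on an aromatic carbon and stays within the scatter. Compound 2 therefore cannot be placed apart from compound 1 on the two numbers measured; the pair reads as one level within the scatter.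

Compound 3 `CC(C)(C)[Si](C)(C)OC[C@H]1O[C@@H](n2cnc3c(O)ncnc32)[C@H](O[Si](C)(C)C(C)(C)C)[C@]12OS(=O)(=O)C=C2N` differs from compound 2 by hydrogen in place of methyl on an oxygen on an aromatic ring; cut one bond further out, the same change reads methoxy to hydroxy. Among the compounds with values here, only one measured step touches this part of the core, a 1.6-fold higher number from compound 1 to compound 2 (0.21 log units; within the scatter), and it moved the number within the scatter when the methoxy group was introduced. Removing the methyl from that oxygen is a change no measured pair covers directly; the data give no reason to expect a shift beyond the scatter in this assay in either direction. The estimate for compound 3 in this assay is 17000 nM, with a range of 7000 nM to 45000 nM, which means an expected step of a 1.2-fold lower number from compound 2 to compound 3 (0.09 log units; within the scatter).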

Compound 3, half-maximal cytotoxic concentration: 14000 nM
Beside the measured number, compound 3's estimate is 1.2-fold (0.08 log units) above it; the range from low to high includes it.
By their numbers in this assay, from the lowest: compounds 1, 3 and 2 (each within the scatter of the next).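

In this assay, the aromatic carbon of the shared core can now be read with three groups on it: hydrogen, methoxy and hydroxy. Hydrogen in place of methyl on the oxygen gives a 1.5-fold lower number from compound 2 to compound 3 (0.18 log units; within the scatter), and hydroxy in place of hydrogen on the aromatic carbon gives a 1.1-fold higher number from compound 1 to compound 3 (0.03 log units; within the scatter), so both new steps stay within the scatter, like the methoxy step before them, and compounds 1, 2 and 3 read as one level, with no compound in the series going against this. Nothing at hand bears on why these three groups read alike in this series.

The compounds shown leave open whether this flat reading extends to groups of another kind on the same aromatic carbon, such as an amine, a carboxylic acid or a longer chain on the oxygen, such as butoxy. They also leave open whether the hydrogen, methoxy and hydroxy groups would still read as one level in this assay on a core without the two tert-butyldimethylsilyl groups that all three compounds share.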